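Bromopyridyl sulfonamide tested against three inactive aryl analogues

The source may report more compounds than this note shows. Statements on the series, on what has been measured and on what is new or still open speak of the compounds shown alone.

Compound 1 `CC1CCN(C2CCN(S(=O)(=O)c3cccc(C(F)(F)F)c3)CC2)CC1`: in an ADME assay on HCT-116 cells (Homo sapiens) for cytotoxicity, read by CellTiter-Glo, with a stated time of 72 h (a lower number here means a stronger inhibitor, a higher number a weaker inhibitor), compound 1 reaches only the assay limit, > 5000 nM.
Compound 2 `COc1ccccc1-c1cccc(S(=O)(=O)N2CCC(N3CCC(C)CC3)CC2)c1`: in this assay compound 2 likewise gives a limit, > 5000 nM.
Compound 3 `Cc1cccc(S(=O)(=O)N2CCC(N3CCC(C)CC3)CC2)c1`: in this assay compound 3 also gives a limit, > 5000 nM.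

Compound 3 thus stands at the limit, as do the other two, since (the limit of > 5000 nM in this assay, at which 3 of the 3 values shown sit). The steps among the measured compounds, a step that the two limits leave unreadable from compound 1 to compound 2, a step that the two limits leave unreadable from compound 1 to compound 3 and a step that the two limits leave unreadable from compound 2 to compound 3, cannot be sized. Compound 4 `CC1CCN(C2CCN(S(=O)(=O)c3cncc(Br)c3)CC2)CC1` differs from compound 3 by 5-bromopyridin-3-yl in place of 3-methylphenyl on a sulfonyl sulfur. Among the measured compounds shown here, none of the measured steps gives a readable size, so no direction beyond the scatter can be foreseen, and a further limit is the likeliest outcome. Compound 4 is therefore estimated at 8000 nM, with an expected range from 3000 nM to 30000 nM. The expected step that the limit leaves unreadable from compound 3 to compound 4 is anticipated to be unreadable against the limit.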

Compound 4, half-maximal inhibitory concentration: > 10000 nM
Compound 4: only a limit was reported (the forecaster's own chance of this, stated with the estimate: 85%); middle value at least 1.2-fold (0.09 log units) away from the limit.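

Compound 3 and compound 4 both give only limits, and the step between them cannot be read. The compounds shown leave open the actual value of each compound and whether any change among them shifts it.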